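Aryl amide variation on the shared core: step toward 3-fluorophenyl

The source may report more compounds than this note shows. Statements on the series, on what has been measured and on what is new or still open speak of the compounds shown alone.

In a functional assay on CHO cells for antagonist activity at Orexin/Hypocretin receptor type 1 (Homo sapiens), read by FLIPR and calcium flux (on this read-out lower numbers stand for stronger inhibition and higher numbers for weaker inhibition), compound 2 `COc1ccc(C)cc1NC(=O)CSc1nnc(-c2ccoc2C)n1Cc1ccco1` gives 2510 nM and stands level with compound 3 `Cc1cccc(NC(=O)CSc2nnc(-c3ccoc3C)n2Cc2ccco2)c1`, which gives 2510 nM. Compound 1 `Cc1cccc(C)c1NC(=O)CSc1nnc(-c2ccoc2C)n1Cc1ccco1` reports only a limit in this assay, > 15800 nM, recorded as the limit of > 15800 nM in this assay, at which 1 of the 3 values shown sits. The two steps away from compound 1 are both clear: an at least 6.2-fold lower number from compound 1 to compound 2 (0.79 log units; beyond the scatter) and an at least 6.2-fold lower number from compound 1 to compound 3 (0.79 log units; beyond the scatter). Between the two aryl amides that do carry a number the step is flat: no change at the digits printed from compound 2 to compound 3 (within the scatter).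

Compound 4 `Cc1occc1-c1nnc(SCC(=O)Nc2cccc(F)c2)n1Cc1ccco1` is the next aryl amide on the same core. The change from compound 2 is 3-fluorophenyl in place of 2-methoxy-5-methylphenyl on an amide-type nitrogen. Among the measured compounds shown here, of the measured steps, the one from compound 2 to compound 3 bears most directly on it, since it also strips the methoxy and leaves a single substituent on the aryl ring, and that step stayed within the scatter. The steps from compound 1 show that a 2,6-dimethylphenyl amide is the only pattern so far that falls to the limit; compound 4 does not return to that pattern. The expectation for compound 4 in this assay is therefore a step of no more than the scatter, a 1.2-fold higher number from compound 2 to compound 4 (0.08 log units; within the scatter). Compound 4 is estimated at 3000 nM, with a range from 1000 nM to 9000 nM.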

Compound 4, inhibition constant: > 15800 nM
Compound 4 was reported as a limit; the forecaster's own chance of this, stated with the estimate: 15%; middle value at least 5.2-fold (0.72 log units) away from the limit.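

The aryl amide position is less forgiving than the earlier flat step among the aryl amides suggested: fluoro in place of methyl on an aromatic carbon gives an at least 6.2-fold higher number from compound 3 to compound 4 (0.79 log units; beyond the scatter), so in this assay carrying a single substituent on the ring does not by itself hold the read-out. The 2-methoxy-5-methylphenyl amide also keeps a clear margin over 3-fluorophenyl, with an at least 6.2-fold higher number from compound 2 to compound 4 (0.79 log units; beyond the scatter), and a fall to the limit is therefore no longer confined to the 2,6-dimethylphenyl amide. Compound 4 is reported only as a limit, as is compound 1, so the step joining these two compounds cannot be read: the limit of > 15800 nM in this assay, at which 2 of the 4 values shown sit.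

On these data alone, how far compound 4 lies past its limit remains open, which leaves the full size of the change unknown. As far as these compounds go, it is also open whether the fall belongs to fluoro specifically or to any replacement of the methyl, a question that a chloro or an amine on the same aromatic carbon would address.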